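Sulfanyl to Selenium-Bearing Group on a Fused Core

This account rests on a few compounds, and the source may have more. Where it says the series, first, only, none or still open, it means among the compounds named here.

Of the compounds shown here, two on a shared core have been measured in an ADME assay on BEAS-2B cells (Homo sapiens) for cytotoxicity, read by MTT assay, with a stated time of 72 h; on this read-out lower numbers stand for stronger inhibition of growth and higher numbers for weaker inhibition of growth. Compound 1 `C[Se]c1nc(N)c2ccccc2n1` gives 23600 nM, while compound 2 `Sc1nc(NCc2ccccc2)c2ccccc2n1` gives 66300 nM. Going by the values given here, compound 2 thus stands highest of the two numbers, and its nearest neighbour is compound 1, whose number is lower by an amount beyond the usual scatter; the two differ in more than one place, so no single step can be drawn between them.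

Compound 3 `C[Se]c1nc(NCc2ccccc2)c2ccccc2n1` has not yet been measured in this assay. It differs from compound 2 in one place: a group of 2 heavy atoms (1 carbon, 1 selenium; no ring) in place of one sulfur atom, on an aromatic carbon. The sulfanyl leaves an aromatic carbon between two ring nitrogen atoms, and the entering group of 2 heavy atoms is the same one carried by compound 1.

Compound 3 is expected to show a downward step of modest size, a 1.9-fold lower number from compound 2 to compound 3 (0.28 log units; within the scatter), because compound 1 gives 23600 nM with that same group. The estimate for compound 3 in this assay is 35000 nM, within a range from 12000 nM to 90000 nM.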

Compound 3, concentration for 50% growth inhibition: 570 nM
Estimate against measurement, compound 3: 61-fold (1.79 log units) above; measured number below the stated range.
By their numbers in this assay, from the lowest: compound 3; then compound 1; then compound 2.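

In this assay, going by these compounds alone, putting the group of 2 heavy atoms in place of the sulfanyl on the aromatic carbon between two ring nitrogen atoms gives a 120-fold lower number from compound 2 to compound 3 (2.07 log units; beyond the scatter), showing that this position can respond far more strongly than the earlier compounds suggested. The same group does not bring so low a number on its own: compound 1 carries it and gives 23600 nM, whereas compound 3 gives 570 nM. No measured evidence here accounts for the size of this step.

The compounds shown leave open whether the step follows the selenium or the added methyl carbon, which a methylsulfanyl group at this position would separate. They also leave open whether a longer chain on the selenium, such as ethyl, would give a similar number.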